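The source may report more compounds than this note shows. Statements on the series, on what has been measured and on what is new or still open speak of the compounds shown alone.

Measured so far:
compound 1 `Cc1nc(-c2ccsc2)sc1COc1ccc2c(c1)OCC2CC(=O)O`: 68.5 nM
compound 2 `Cc1nc(-c2cccc3ccccc23)sc1COc1ccc2c(c1)OCC2CC(=O)O`: "not determined" (no result reported)
compound 3 `Cc1nc(-c2ccccc2C(F)(F)F)sc1COc1ccc2c(c1)OCC2CC(=O)O`: "not determined" (no result reported)

Three compounds share one core and differ only in the aryl group on the five-membered ring. In a functional assay on CHO cells for agonist activity at Free fatty acid receptor 1 (Homo sapiens), read by FLIPR and calcium flux (on this read-out higher numbers stand for an effect only at larger amounts of compound and lower numbers for an effect already at smaller amounts), compound 1 gives 68.5 nM. Among the measured compounds shown here, compound 2 has no number in this assay, and compound 3 has none either, so compound 2 cannot be placed against compound 1 and there is no step between measured compounds to draw on. Compound 4 `COc1ccc(-c2nc(C)c(COc3ccc4c(c3)OCC4CC(=O)O)s2)cc1` is the next member. It differs from compound 2 by 4-methoxyphenyl in place of naphthalen-1-yl on an aromatic carbon. Compound 2 offers no value. The step from compound 2 to compound 4 in this assay therefore cannot be given a size or a direction; compound 1 is the only anchor. On that basis compound 4 is expected to give about 120 nM in this assay, estimated to lie between 30 nM and 500 nM.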

Compound 4, half-maximal effective concentration: 123 nM
Compound 4: middle estimate off by 1.0-fold (0.01 log units), on the low side; the range from low to high includes it.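

Among the compounds shown here, this is the first readable step at this position: in this assay, 4-methoxyphenyl in place of thiophen-3-yl gives a 1.8-fold higher number from compound 1 to compound 4 (0.25 log units; within the scatter), so compound 1 and compound 4 cannot be told apart. A six-membered carbon ring bearing a methoxy group and a thiophene ring are therefore both compatible with an effect in this assay, at least for these two compounds. Nothing available explains this result.

Compound 2 and compound 3 have no number, so their steps cannot be read. On these data alone, how a pyridine ring or an aminophenyl group would behave at this position also remains open.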